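Three sulfonamides and a dimethylphenyl question

The source may hold more compounds than are shown below. What is called first, only, known or untested is meant among the compounds shown, and "the series" means these compounds.

Values in a functional assay on M21 cells (Homo sapiens) for antiproliferative activity, read by sulforhodamine B assay, with a stated time of 48 h (a higher number here means a weaker inhibitor, a lower number a stronger inhibitor), for the measured compounds

compound 1 (`O=C1NCCN1c1ccc(S(=O)(=O)Nc2ccc(I)cc2)cc1`) gives 260 nM
compound 2 (`Cc1cc(C)cc(NS(=O)(=O)c2ccc(N3CCNC3=O)cc2)c1`) gives 63 nM
compound 3 (`O=C1NCCN1c1ccc(S(=O)(=O)Nc2ccc(Cl)cc2)cc1`) gives 90 nM

Compound 3 stands in the lower pair of these numbers. Two measured steps place it, namely a 1.4-fold higher number from compound 2 to compound 3 (0.15 log units; within the scatter) and a 2.9-fold lower number from compound 1 to compound 3 (0.46 log units; beyond the scatter) on the other side of the set.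

In compound 4 (`Cc1cccc(NS(=O)(=O)c2ccc(N3CCNC3=O)cc2)c1C`) 2,3-dimethylphenyl stands in place of 4-chlorophenyl on a sulfonamide nitrogen (2,3-dimethylphenyl in place of 4-chlorophenyl on a sulfonamide nitrogen) and the rest of the molecule is unchanged.

The closest evidence is the exchange of the same two kinds of group, a 1.4-fold higher number from compound 2 to compound 3 (0.15 log units; within the scatter) and so no real separation between a dimethylphenyl and the 4-chlorophenyl. The exchange at this same nitrogen that did move the number, a 4.1-fold lower number from compound 1 to compound 2 (0.62 log units; beyond the scatter) as a modest step, started from the 4-iodophenyl group, which compound 4 does not involve. Among the compounds with values here, no measured compound carries the 2,3-dimethylphenyl group, so its own effect remains unknown and the range must stay wide. In this assay the expected step is a 1.1-fold lower number from compound 3 to compound 4 (0.05 log units; within the scatter) and nothing beyond the scatter is anticipated. For compound 4 the estimated value is 80 nM with an expected range from 30 nM to 220 nM in this estimate.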

Compound 4, half-maximal inhibitory concentration: 110 nM
Beside the measured number, compound 4's estimate is 1.4-fold (0.14 log units) below it, and the stated range covers the measured number.
By their numbers in this assay, from the lowest: compounds 2, 3 and 4 (each within the scatter of the next); then compound 1.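

In this assay, the 2,3-dimethylphenyl group on the sulfonamide nitrogen cannot be told apart from the 4-chlorophenyl group (a 1.2-fold higher number from compound 3 to compound 4 (0.09 log units; within the scatter)), and the two dimethylphenyl patterns are not separated either (a 1.7-fold higher number from compound 2 to compound 4 (0.24 log units; within the scatter)). Within the data shown here, the earlier compounds had offered only one dimethylphenyl pattern, so this is the first sign that the arrangement of the two methyl groups on this phenyl ring makes no measurable difference here, while the step from the 4-iodophenyl group (a 2.4-fold lower number from compound 1 to compound 4 (0.37 log units; beyond the scatter)) shows that compound 1 again stands apart, now from all three other compounds. Among these four compounds, then, compound 2, compound 3 and compound 4 form one group with compound 1 as the sole exception, and no evidence is available to explain that separation.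

The compounds shown leave open whether a 4-bromophenyl group would fall with the 4-chlorophenyl group or with the 4-iodophenyl group. They also leave open whether a phenyl ring carrying a methoxy group, an amine or a carboxylic acid on this nitrogen would stay within the same group of numbers.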